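The compounds below may be only part of what the source reports. "The series", "measured", "known", "first", "only" and "open" are said of these compounds alone.

Measured compounds and their values:

Compound 1, `O=C(CSc1nnc(-c2ccncc2)o1)N/N=C/c1ccc(F)cc1`, gives 12300 nM in a functional assay on HepG2 cells (Homo sapiens) for cytotoxicity, read by MTT assay, with a stated time of 48 h; a lower number here means a stronger inhibitor, a higher number a weaker inhibitor.
Compound 2, `O=C(CSc1nnc(-c2ccncc2)o1)N/N=C/c1ccccc1F`, gives 16000 nM in this assay.
Compound 3, `O=C(CSc1nnc(-c2ccncc2)o1)N/N=C/c1cc(Cl)ccc1O`, gives 3970 nM in this assay.

Compound 3 stands lowest of the three in this assay: compound 1 is the nearest, with a 3.1-fold lower number from compound 1 to compound 3 (0.49 log units; beyond the scatter), and compound 2 the furthest, with a 4.0-fold lower number from compound 2 to compound 3 (0.61 log units; beyond the scatter). Between compound 1 and compound 2 the difference, a 1.3-fold higher number from compound 1 to compound 2 (0.11 log units; within the scatter), is within the scatter.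

Compound 4, `O=C(CSc1nnc(-c2ccncc2)o1)N/N=C/c1cc(Br)cc(Br)c1O`, has not yet been measured. It differs from compound 3 in one place: 3,5-dibromo-2-hydroxyphenyl in place of 5-chloro-2-hydroxyphenyl on a carbon with a double bond to nitrogen. The hydroxyl on the ring is kept; what changes is the halogen pattern on it.

For the measured compounds named here, no measured step swaps one halogen for another on this ring or adds a second one, so no step bears directly on the change. The two steps into compound 3, a 3.1-fold lower number from compound 1 to compound 3 (0.49 log units; beyond the scatter) and a 4.0-fold lower number from compound 2 to compound 3 (0.61 log units; beyond the scatter), show that a halogenated ring carrying the hydroxyl gave the lowest number, and compound 4 keeps that feature. Compound 4 is therefore expected to land near compound 3, with a 1.3-fold lower number from compound 3 to compound 4 (0.12 log units; within the scatter) as the expected step, a small move in either direction being plausible. The estimate for compound 4 in this assay is 3000 nM, with a range from 1000 nM to 9000 nM.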

Compound 4, half-maximal inhibitory concentration: 6540 nM
The estimate for compound 4 lay 2.2-fold (0.34 log units) below the measured number, within the range that was stated.
By their numbers in this assay, from the lowest: compounds 3, 4, 1 and 2 (each within the scatter of the next, the first and the last beyond it).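

In this assay, the step of a 1.6-fold higher number from compound 3 to compound 4 (0.22 log units; within the scatter) shows that the 5-chloro-2-hydroxyphenyl group and the 3,5-dibromo-2-hydroxyphenyl group cannot be told apart at this position, on a carbon with a double bond to nitrogen, so this change in halogen pattern on a ring that keeps its hydroxyl has no effect that can be read here. Against the fluorinated rings the dibromo compound separates less clearly than the chloro compound did: a 2.4-fold lower number from compound 2 to compound 4 (0.39 log units; beyond the scatter) lies beyond the scatter, while a 1.9-fold lower number from compound 1 to compound 4 (0.27 log units; within the scatter) stays within it, so compound 4 stands clear of only one of the two fluorophenyl compounds, whereas compound 3 stood clear of both. Nothing in the data at hand accounts for this result.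

The compounds shown change the halogens and the hydroxyl together, so what each contributes on its own stays unresolved, as does the separate effect of replacing chlorine with bromine and of adding a second halogen. Going by these compounds, how a methoxy group or an amine would behave in place of the hydroxyl on this ring also remains open.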